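Trimming the aryl ring of a glycine transporter inhibitor

The compounds below may be only part of what the source reports. "The series", "measured", "known", "first", "only" and "open" are said of these compounds alone.

Of the compounds shown here, three share one core and have been tested in an assay on isolated protein for inhibition of sodium- and chloride-dependent glycine transporter 1 (Homo sapiens); on this read-out lower numbers stand for stronger inhibition and higher numbers for weaker inhibition. Compound 2 `CCCS(=O)(=O)N1CCC(CNC(=O)c2c(F)ccc(Cl)c2F)(C(=O)N2CCOCC2)CC1` gives 8.4 nM, the lowest of the three. For the measured compounds named here, compound 1 `CCCS(=O)(=O)N1CCC(CNC(=O)c2ccc(Cl)cc2Cl)(C(=O)N2CC(N)C2)CC1` gives 109 nM, and compound 3 `CCCS(=O)(=O)N1CCC(CNC(=O)c2ccc(Cl)cc2Cl)(C(=O)NCC)CC1` gives 517 nM; the only single-place step, a 4.7-fold higher number from compound 1 to compound 3 (0.68 log units; beyond the scatter), concerns the group on the other carbonyl carbon, not the aryl ring. Compound 4 `CCCS(=O)(=O)N1CCC(CNC(=O)c2ccccc2Cl)(C(=O)N2CCOCC2)CC1` differs from compound 2 by 2-chlorophenyl in place of 3-chloro-2,6-difluorophenyl on a carbonyl carbon. Going by the values given here, no measured step touches this ring, so the direction rests on general experience that stripping substituents tends to weaken binding. Compound 4 is expected to show a 4.8-fold higher number from compound 2 to compound 4 (0.68 log units; beyond the scatter), an estimated 40 nM in this assay, within 10 nM to 160 nM.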

Compound 4, half-maximal inhibitory concentration in the sodium- and chloride-dependent glycine transporter 1 assay: 9.7 nM
Beside the measured number, compound 4's estimate is 4.1-fold (0.62 log units) above it; measured number below the stated range.
By their numbers in the sodium- and chloride-dependent glycine transporter 1 assay, from the lowest: compounds 2 and 4 (each within the scatter of the next); then compound 1; then compound 3.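

In the sodium- and chloride-dependent glycine transporter 1 assay, going from 3-chloro-2,6-difluorophenyl to 2-chlorophenyl gives a 1.2-fold higher number from compound 2 to compound 4 (0.06 log units; within the scatter) and so shows that this position tolerates losing both fluorine atoms and moving the chlorine. In a physicochemical assay for solubility (on this read-out higher numbers stand for higher solubility and lower numbers for lower solubility), compound 2 gives 10000 ug/mL and compound 4 gives 10000 ug/mL so that read-out shows no difference either. Nothing measured here explains this tolerance. Still open, going by these compounds, is whether a plain phenyl, or a methoxy or nitrile group in place of the chlorine, would hold up as well. Also open, on these data alone, is how 2-chlorophenyl behaves alongside the ethylamino or 3-aminoazetidin-1-yl group on the other carbonyl carbon.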